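The source may report more compounds than this note shows. Statements on the series, on what has been measured and on what is new or still open speak of the compounds shown alone.

Measured in an ADME assay on L929 cells (Mus musculus) for cytotoxicity, read by resazurin assay, with a stated time of 96 h; on this read-out lower numbers stand for higher toxicity in this test and higher numbers for lower toxicity in this test:
- compound 1 `CCc1ccc(OC/C(=N\NC(N)=S)c2ccc(Br)cc2)cc1`: < 25500 nM (a limit of the assay, not a number)
- compound 2 `CC(=O)Nc1ccc(OC/C(=N\NC(N)=S)c2ccc(Br)cc2)cc1`: 94900 nM
- compound 3 `NC(=S)N/N=C(\COc1ccc(F)cc1)c1ccc(Br)cc1`: 52300 nM

Compound 3 gives 52300 nM, and it cannot be told apart from compound 2: a 1.8-fold lower number from compound 2 to compound 3 (0.26 log units; within the scatter). Compound 1 has only a limit, < 25500 nM. Measured against that limit, the record shows an at least 2.0-fold higher number from compound 1 to compound 3 (0.31 log units; beyond the scatter) and also an at least 3.7-fold higher number from compound 1 to compound 2 (0.57 log units; beyond the scatter).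

The next compound, compound 4 `NC(=S)N/N=C(\COc1ccc(Cl)cc1)c1ccc(Br)cc1`, differs from compound 3 in one place: chloro in place of fluoro on an aromatic carbon. This puts chloro in place of fluoro on an aromatic carbon, para to a large group. Going by the values given here, no measured step makes this exact exchange, so the guidance comes from other exchanges at the same place. The two steps from compound 1 start from a limit, so they give only a minimum size. The exchange of acetamido for fluoro stayed small, a 1.8-fold lower number from compound 2 to compound 3 (0.26 log units; within the scatter), so only a small change is expected here too.

In this assay the expected step is a 1.2-fold lower number from compound 3 to compound 4 (0.07 log units; within the scatter), which is estimated to stay within the scatter. For compound 4 the estimate is 45000 nM, with an expected range from 20000 nM to 95000 nM.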

Compound 4, half-maximal cytotoxic concentration: < 25100 nM
Compound 4 ended at the assay's limit; the forecaster's own chance of this, stated with the estimate: 15%; at least 1.7-fold (0.25 log units) between middle value and limit.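

In this assay, exchanging one halogen for another, 4-fluorophenyl to 4-chlorophenyl, is enough to shift the read-out toward higher toxicity in this test: an at least 2.0-fold lower number from compound 3 to compound 4 (0.31 log units; beyond the scatter). The acetamido compound also stands clearly apart from the chloro compound, an at least 3.7-fold lower number from compound 2 to compound 4 (0.57 log units; beyond the scatter), although acetamido and fluoro could not be told apart at this same place, so a small change here is not the rule for every exchange. Going by these compounds, compound 4 gives a limit of the assay and not a number, so the true size of both steps stays open: the limit of < 25100 nM in this assay, at which 1 of the 4 values shown sits.

Compound 1 and compound 4 both carry limits, so the step between them cannot be read. On these data alone, how a bromo, a methoxy or an amine at this place would compare, and whether any of them would give a number rather than a limit, remains open.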